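The compounds below may be only part of what the source reports. "The series", "measured", "known", "first", "only" and "open" are said of these compounds alone.

Compound 1 `Cc1cc(C)c(Oc2cc(Nc3ccc(C#N)cc3)ncc2C(=O)NCc2cn(Cc3cccc([N+](=O)[O-])c3)nn2)c(C)c1`: in an ADME assay on MT4 cells (Homo sapiens) for cytotoxicity, read by MTT assay, with a stated time of 5 days (a lower number here means that less compound is tolerated, a higher number that more compound is tolerated), compound 1 gives >= 156000 nM, a limit of the assay. Compound 2 `Cc1cc(C)c(Oc2cc(Nc3ccc(C#N)cc3)ncc2C(=O)NCc2cn(Cc3ccc(Cl)cc3)nn2)c(C)c1`: in this assay compound 2 gives >= 120000 nM, also a limit. Compound 3 `Cc1cc(C)c(Oc2cc(Nc3ccc(C#N)cc3)ncc2C(=O)NCc2cn(Cc3ccccc3C)nn2)c(C)c1`: in this assay compound 3 gives >= 164000 nM, again a limit.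

Compound 2 thus stands only at a limit, and the two further values are limits as well. Compound 4 `Cc1cc(C)c(Oc2cc(Nc3ccc(C#N)cc3)ncc2C(=O)NCc2cn(Cc3ccccc3Cl)nn2)c(C)c1` differs from compound 2 by 2-chlorophenyl in place of 4-chlorophenyl on a saturated chain carbon bound to an aromatic nitrogen. The steps that touch the 4-chlorophenyl are a step that the two limits leave unreadable from compound 1 to compound 2 and a step that the two limits leave unreadable from compound 2 to compound 3, and a step that the two limits leave unreadable from compound 1 to compound 3 is of the same kind; each rests on a limit, (the limit of >= 120000 nM in this assay, at which 1 of the 3 values shown sits), the limit of >= 156000 nM in this assay, at which 1 of the 3 values shown sits, and (the limit of >= 164000 nM in this assay, at which 1 of the 3 values shown sits), so no size can be read. No step beyond the scatter is therefore expected in this assay for compound 4, whose value is estimated as 120000 nM, between 60000 nM and 240000 nM, with a number no higher from compound 2 to compound 4 (the limit leaves the size open).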

Compound 4, half-maximal cytotoxic concentration: >= 188000 nM
Compound 4 gave a limit, no number (the forecaster's own chance of this, stated with the estimate: 85%); at least 1.5-fold (0.19 log units) between middle value and limit.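

In this assay compound 4 gives >= 188000 nM, a limit, and its steps to compound 1, compound 2 and compound 3, which also stand at limits, cannot be read. The compounds shown leave open whether 2-chlorophenyl in place of 4-chlorophenyl changes the tolerated concentration at all.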